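What Happens When the Amino Group Leaves Compound 3?

The compounds below may be only part of what the source reports. "The series", "measured", "known", "first", "only" and "open" are said of these compounds alone.

Going by the values given here, in a functional assay on HepG2 cells (Homo sapiens) for cytotoxicity, read by sulforhodamine B assay, with a stated time of 48 h (a higher number here means a weaker inhibitor, a lower number a stronger inhibitor), three related compounds have numbers so far. Compound 1 `COc1ccc(/C=C/C(=O)c2cccc(-c3ccc(F)cc3)c2)cc1` gives 5650 nM, compound 2 `COc1ccc(/C=C/C(=O)c2cccc(-c3cccc(F)c3)c2)cc1OC` gives 1170 nM, and compound 3 `COc1ccc(/C=C/C(=O)c2ccc(N)c(-c3ccc(F)cc3)c2)cc1OC` gives 3780 nM. Compound 3 therefore sits within the scatter of compound 1, while compound 2 shows a lower number, beyond the scatter of compound 3.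

The next compound, compound 4 `COc1ccc(/C=C/C(=O)c2cccc(-c3ccc(F)cc3)c2)cc1OC`, has hydrogen in place of amino on an aromatic carbon, ortho to a 4-fluorophenyl group (hydrogen in place of amino on an aromatic carbon). Among the compounds with values here, no measured pair shows this change on its own, so its size can only be estimated. Compound 2 also lacks the amino group and gives 1170 nM, as does compound 1 at 5650 nM, and these two values bracket the number for compound 3. A small shift toward a stronger inhibitor is expected, probably within the scatter, with an estimated 1.4-fold lower number from compound 3 to compound 4 (0.13 log units; within the scatter). The estimate for compound 4 is 2800 nM, with an expected range of 1000 nM to 8000 nM.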

Compound 4, half-maximal inhibitory concentration: 5370 nM
Beside the measured number, compound 4's estimate is 1.9-fold (0.28 log units) below it; the measured number falls inside the stated range.
By their numbers in this assay, from the lowest: compound 2; then compounds 3, 4 and 1 (each within the scatter of the next).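

Replacing amino with hydrogen gives a 1.4-fold higher number from compound 3 to compound 4 (0.15 log units; within the scatter) in this assay, so at this position, ortho to a 4-fluorophenyl group, the two compounds cannot be told apart. A difference beyond the scatter appears instead with 4-fluorophenyl in place of 3-fluorophenyl, which gives a 4.6-fold higher number from compound 2 to compound 4 (0.66 log units; beyond the scatter), whereas methoxy in place of hydrogen gives a 1.1-fold lower number from compound 1 to compound 4 (0.02 log units; within the scatter), a step within the scatter. No supporting data are available to explain any of these steps.

The compounds shown leave open whether a hydroxyl group, an acetamide or a larger amine at the amino position would also stay within the scatter of compound 4. They also leave open whether amino and hydrogen would remain indistinguishable alongside the 3-fluorophenyl group of compound 2.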